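Moving a Substituent Around the Benzyl Ring

A few compounds are considered here, and "the series" means these few. Any claim that something is new, unique, unknown or untested is made for them only; others in the source may bear on it.

Measured in a functional assay on CHO cells for positive allosteric modulation of muscarinic acetylcholine receptor M5 (Homo sapiens), read by calcium flux; on this read-out higher numbers stand for larger maximal responses and lower numbers for smaller maximal responses:
compound 1, `CCN(Cc1cccc(C)c1)C(=O)C1CCN(S(=O)(=O)c2ccc3cn[nH]c3c2)CC1`, gives 78%
compound 2, `CCN(Cc1ccccc1C)C(=O)C1CCN(S(=O)(=O)c2ccc3cn[nH]c3c2)CC1`, gives 103%

Going by the values given here, compound 2 stands highest of the two measured numbers; its only neighbour, compound 1, lies lower, and the change from compound 1 to compound 2 is a number 25 percentage points higher from compound 1 to compound 2 (beyond the scatter). Among the compounds with values here, that is the single step known so far, and it rests on moving a methyl group from one place on the phenyl ring to another, with 2-methylphenyl replacing 3-methylphenyl.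

Compound 3, `CCN(Cc1cccc(C(F)(F)F)c1)C(=O)C1CCN(S(=O)(=O)c2ccc3cn[nH]c3c2)CC1`, has not yet been measured. The change from compound 2 to compound 3 is 3-(trifluoromethyl)phenyl in place of 2-methylphenyl on a saturated chain carbon bound to an amide-type nitrogen. Two things change at once: the substituent returns to the placement it held in compound 1, and methyl becomes trifluoromethyl. Within the data shown here, no measured step covers the second change. Among the measured compounds shown here, the one step that bears on it, a number 25 percentage points higher from compound 1 to compound 2 (beyond the scatter), ran upward when 3-methylphenyl gave way to 2-methylphenyl, so the reverse direction is expected here, though the new group may soften or sharpen it in a way the data cannot show. Compound 3 is therefore expected to give 75%, between 50% and 100%, an expected step of a number 28 percentage points lower from compound 2 to compound 3 (beyond the scatter) in this assay.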

Compound 3, largest response reached (reported as percent of maximum), in percent of the reference or control that the assay uses: 59%
Estimate against measurement, compound 3: 16 percentage points above; the range from low to high includes it.
By their numbers in this assay, from the lowest: compound 3; then compound 1; then compound 2.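

Trifluoromethyl in place of methyl on an aromatic carbon gives a number 19 percentage points lower from compound 1 to compound 3 (beyond the scatter) in this assay, so the maximal response at this position depends on which group the phenyl ring carries, and not only on where that group sits. Replacing 2-methylphenyl with 3-(trifluoromethyl)phenyl alters both the group and its placement and gives a number 44 percentage points lower from compound 2 to compound 3 (beyond the scatter), a large step, whereas the other two steps among these compounds are modest, and both changes away from compound 2 lower the response. The data at hand offer nothing that explains why the response falls when trifluoromethyl replaces methyl.

As far as these compounds go, how a chlorine atom, a methoxy group or a plain phenyl ring would fare on this saturated chain carbon bound to an amide-type nitrogen remains open. Also open, from the compounds shown here alone, is whether the higher response of 2-methylphenyl compared with 3-methylphenyl carries over to groups other than methyl, since a single pair of compounds cannot establish a general rule for this ring.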